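A Trifluoromethylphenyl Variant of an Inactive Pair

The compounds below may be only part of what the source reports. "The series", "measured", "known", "first", "only" and "open" are said of these compounds alone.

Compound 1, `Cc1cc(=O)n(-c2ccccc2OC(F)(F)F)nc1C(=O)Nc1ccc(Oc2ncnc3c2ccn3C)c(F)c1`: > 60000 nM
Compound 2, `Cc1ccc(-n2nc(C(=O)Nc3ccc(Oc4ncnc5c4ccn5C)c(F)c3)c(C)cc2=O)cc1`: > 60000 nM

In a functional assay on MCF7 cells (Homo sapiens) for cytotoxicity, read by MTT assay, with a stated time of 72 h (a lower number here means a stronger inhibitor, a higher number a weaker inhibitor), compound 1 gives > 60000 nM, which is a limit of the assay rather than a number. Compound 2 gives > 60000 nM, again a limit. Among the measured compounds shown here, the single measured step, a step that the two limits leave unreadable from compound 1 to compound 2, therefore cannot be read. Compound 2 stands at the limit of > 60000 nM in this assay, at which 2 of the 2 values shown sit. Compound 3, `Cc1cc(=O)n(-c2ccccc2C(F)(F)F)nc1C(=O)Nc1ccc(Oc2ncnc3c2ccn3C)c(F)c1`, differs from compound 2 by 2-(trifluoromethyl)phenyl in place of 4-methylphenyl on an aromatic nitrogen. For the measured compounds named here, the one measured step concerns a swap at the same aromatic nitrogen, and because both of its ends sit at the limit of > 60000 nM in this assay, at which 2 of the 2 values shown sit, it yields neither a size nor a direction. The 2-(trifluoromethyl)phenyl of compound 3 resembles the 2-(trifluoromethoxy)phenyl of compound 1 more than the 4-methylphenyl of compound 2. The step expected from compound 2 to compound 3 is a step that the limit leaves unreadable from compound 2 to compound 3, within the scatter. Compound 3 is estimated at 80000 nM, between 25000 nM and 300000 nM, and is expected most likely to be reported only as a limit.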

Compound 3, half-maximal inhibitory concentration: > 60000 nM
Compound 3: no number, only a limit; the forecaster's own chance of this, stated with the estimate: 85%; the middle value does not contradict the limit.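

Compound 3 also gives only a limit of the assay and not a number, so no step among compound 1, compound 2 and compound 3 can be read: the limit of > 60000 nM in this assay, at which 3 of the 3 values shown sit.

Going by these compounds, whether the groups on the aromatic nitrogen differ in their effect on these cells remains open.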